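Working notes: amide variation and metabolic stability

A few compounds are considered here, and "the series" means these few. Any claim that something is new, unique, unknown or untested is made for them only; others in the source may bear on it.

Three compounds of the series have numbers in an ADME assay on microsomes from liver (Homo sapiens) for metabolic stability, read by LC-MS, using NADPH, with a stated time of 45 min, tested at 0.5 uM; on this read-out higher numbers stand for fast clearance and lower numbers for slow clearance. Compound 1 `O=C(CCCSc1nc2cc(Cl)ccc2o1)N1CCCC1` gives 3.4 mL/min/g. Compound 3 `O=C(CCSc1nc2cc(F)c(F)cc2o1)N1CCCC1` gives 6.5 mL/min/g. Compound 2 `O=C(CCSc1nc2cc(Cl)ccc2o1)NC1CCCC1` gives 11.3 mL/min/g, the highest of the three numbers; its gap to compound 3 lies within the usual scatter, whereas its gap to compound 1 lies beyond it, so compound 2 is cleared faster than compound 1 but cannot be told apart from compound 3. Among the compounds with values here, no two of the measured compounds differ in a single place, so no step between measured compounds is available to guide the next change.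

Compound 4 `O=C(CCSc1nc2cc(Cl)ccc2o1)N1CCS(=O)(=O)C1` alters the amide end of compound 2: 1,1-dioxo-1,3-thiazolidin-3-yl in place of cyclopentylamino on a carbonyl carbon. Within the data shown here, no measured pair carries this change, so its outcome can only be framed as an expectation. That slower clearance is reachable within this series is shown by compound 1, which gives 3.4 mL/min/g in this assay. For compound 4 a decrease beyond the scatter is expected, of the size a 2.5-fold lower number from compound 2 to compound 4 (0.40 log units; beyond the scatter). Compound 4 is therefore estimated at 4.5 mL/min/g in this assay, with a range from 1.5 mL/min/g to 11 mL/min/g, pending the measurement.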

Compound 4, intrinsic clearance in a liver preparation (reported as CLH), per the amount of preparation that the assay uses: 1.7 mL/min/g
Estimate against measurement, compound 4: 2.6-fold (0.42 log units) above; low and high end bracket the measured number.
By their numbers in this assay, from the lowest: compounds 4, 1, 3 and 2 (each within the scatter of the next, the first and the last beyond it).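

In this assay, within the data shown here, 1,1-dioxo-1,3-thiazolidin-3-yl in place of cyclopentylamino on a carbonyl carbon gives a 6.6-fold lower number from compound 2 to compound 4 (0.82 log units; beyond the scatter), the first single-place step, and it shows that the amide end alone can move this read-out beyond the scatter with the rest of compound 2 unchanged. Several counted differences travel together in this one step: the entering group has no hydrogen-bond donor, while it has hydrogen-bond acceptors, ring hetero atoms and double bonds outside aromatic rings that the leaving group lacks, so the step cannot be assigned to any one of them. Nothing shown here gives a measured reason for the lower number.

As far as these compounds go, what remains open is which part of the entering group carries the step: a thiazolidin-3-yl ring without the two oxygens on sulfur, or a morpholin-4-yl group, on the same carbonyl carbon would help to separate these features. From the compounds shown here alone, it is also open whether the same step holds on the longer chain of compound 1 or on the difluoro core of compound 3.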